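Stereocentre inversion in a para-iodo carbamate series

The source may hold more compounds than are shown below. What is called first, only, known or untested is meant among the compounds shown, and "the series" means these compounds.

The three measured compounds share a methylene lactone core linked through a two-carbon chain to an aryl carbamate. In an ADME assay on RAW264.7 cells (Mus musculus) for cytotoxicity, read by MTT assay, with a stated time of 18 h (a lower number here means that less compound is tolerated, a higher number that more compound is tolerated), compound 1 `C=C1C(=O)OC[C@@H]1CCOC(=O)Nc1ccc(C(C)C)cc1` gives 15300 nM, compound 2 `C=C1C(=O)OC[C@H]1CCOC(=O)Nc1ccc(I)cc1` gives 12800 nM, and compound 3 `C=C1C(=O)OC[C@H]1CCOC(=O)Nc1ccc(C(=O)OCCCC)cc1` gives 8940 nM. Compound 2 thus stands second highest of the three numbers; its nearest neighbour is compound 1 and its furthest is compound 3, both within the scatter. Among the measured compounds shown here, the one single-point step available, a 1.4-fold lower number from compound 2 to compound 3 (0.16 log units; within the scatter), also stays within the scatter.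

Compound 4 `C=C1C(=O)OC[C@@H]1CCOC(=O)Nc1ccc(I)cc1` differs from compound 2 only in configuration: the two compounds have the same atoms and bonds and differ only in configuration as drawn: 1 of 1 stereo elements differ; a stereocentre at a saturated ring carbon is drawn S in compound 2 and R in compound 4. For the measured compounds named here, no measured pair isolates such an inversion; compound 1 is drawn with the opposite configuration to compound 2 but also carries a different aryl substituent, so its value cannot be read as a stereochemical effect. With this assay showing only small movements across the series, compound 4 is expected to show no step beyond the scatter, no change at the digits printed from compound 2 to compound 4 (within the scatter). Compound 4 is therefore estimated at 12800 nM, within 7000 nM to 23000 nM.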

Compound 4, half-maximal cytotoxic concentration: 12500 nM
For compound 4 the middle estimate is 1.0-fold (0.01 log units) above the measured one; low and high end bracket the measured number.
By their numbers in this assay, from the lowest: compounds 3, 4, 2 and 1 (each within the scatter of the next).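

In this assay, among the compounds shown here, inverting the stereocentre at a saturated ring carbon gives a 1.0-fold lower number from compound 2 to compound 4 (0.01 log units; within the scatter), the first step that isolates this configuration, and the comparison is a clean one: the fact that compounds 2 and 4 differ only in the configuration as drawn. For the compounds shown here, compound 1 and compound 4 share the R configuration as drawn, so they also give the first reading of an aryl substituent within that configuration: a 1.2-fold lower number from compound 1 to compound 4 (0.09 log units; within the scatter). Neither the inversion nor iodo in place of isopropyl on an aromatic carbon therefore moves the number beyond the scatter.

Going by these compounds alone, the inversion is seen only with iodo on the aromatic carbon, so it remains open whether it would read the same with the butoxycarbonyl group of compound 3. Going by these compounds, it is equally open how either configuration would read with an amine or a carboxylic acid on that carbon.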